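Trifluoromethylphenyl placement carried over to a second core

A few compounds are considered here, and "the series" means these few. Any claim that something is new, unique, unknown or untested is made for them only; others in the source may bear on it.

Measured so far:
compound 1, `Cc1nc(N(C)C(=O)NC(=O)c2c(F)cccc2F)sc1C(=O)N/N=C/c1cccc(C(F)(F)F)c1`, in a functional assay on HeLa cells (Homo sapiens) for inhibition, read by MTT assay, with a stated time of 72 h (on this read-out lower numbers stand for stronger inhibition and higher numbers for weaker inhibition), compound 1 gives 26.8 ug/mL
compound 2, `Cc1nc(N(C)C(=O)NC(=O)c2c(F)cccc2F)sc1C(=O)N/N=C/c1ccccc1C(F)(F)F`, compound 2 gives 6.51 ug/mL
compound 3, `CN(C(=O)NC(=O)c1ccccc1F)c1nc(C(F)(F)F)c(C(=O)N/N=C/c2ccccc2C(F)(F)F)s1`, compound 3 gives 10.1 ug/mL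

Compounds 1 and 2 share one core and differ only in the aryl group on the hydrazone carbon. The change there is 3-(trifluoromethyl)phenyl in place of 2-(trifluoromethyl)phenyl on a carbon with a double bond to nitrogen, and it produced the step of a 4.1-fold higher number from compound 2 to compound 1 (0.61 log units; beyond the scatter). Compound 3 is built on a different core; the difference between the two cores is not broken down here. Its value lies close to that of compound 2, within the usual scatter, while its gap to compound 1 is beyond the scatter.

Compound 4, `CN(C(=O)NC(=O)c1ccccc1F)c1nc(C(F)(F)F)c(C(=O)N/N=C/c2cccc(C(F)(F)F)c2)s1`, has not yet been measured in this assay. It differs from compound 3 by 3-(trifluoromethyl)phenyl in place of 2-(trifluoromethyl)phenyl on a carbon with a double bond to nitrogen, the same change, at the same place, that separates compound 2 from compound 1.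

For compound 4 the step of a 3.5-fold higher number from compound 3 to compound 4 (0.54 log units; beyond the scatter) in this assay is expected, and it rests on the step of a 4.1-fold higher number from compound 2 to compound 1 (0.61 log units; beyond the scatter) seen for the same change on the first core. Within the data shown here, because the step of a 4.1-fold higher number from compound 2 to compound 1 (0.61 log units; beyond the scatter) is the only example of the change and was observed on a different core, the expected range for compound 4 is kept wide. Compound 4 is estimated at 35 ug/mL, with the expected range running from 14 ug/mL to 90 ug/mL.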

Compound 4, half-maximal inhibitory concentration: 19.1 ug/mL
Compound 4: the middle estimate sits 1.8-fold (0.26 log units) above what was measured; measured number inside the range.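

On the core of compound 3, 3-(trifluoromethyl)phenyl in place of 2-(trifluoromethyl)phenyl on a carbon with a double bond to nitrogen gives a 1.9-fold higher number from compound 3 to compound 4 (0.28 log units; within the scatter), so on this core the change does not separate the two compounds in this assay. Set beside the step on the first core, the new step does not differ from it by more than the two steps' combined scatter: the same change on two cores in this assay, a 4.1-fold higher number (0.61 log units; beyond the scatter) from compound 2 to compound 1 and a 1.9-fold higher number (0.28 log units; within the scatter) from compound 3 to compound 4, 2.2-fold (0.34 log units) apart, within the scatter of two such steps. Among these compounds, the pairs are therefore compatible with the change carrying over from one core to the other at a similar size, but they do not show that it does, since the step lies beyond the scatter on one core and within it on the other, and each core offers only a single pair, which is too little to establish either transfer or a dependence on the core.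

Going by these compounds, the two cores differ in more than one place, so which of those differences matters for the read-out stays open, as does whether the same pattern would hold in cells other than HeLa. Also open, on these data alone, is how a plain phenyl, or an aryl group carrying a nitrile, a methoxy group or a carboxylic acid instead of trifluoromethyl, would behave on that carbon on either core.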